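Two Hydroxy Groups on the Phenyl of Compound 1

A few compounds are considered here, and "the series" means these few. Any claim that something is new, unique, unknown or untested is made for them only; others in the source may bear on it.

Compound 1, `O=C(CC(c1ccccc1)c1c[nH]c2ccccc12)c1c(O)c2ccccc2oc1=O`, carries a plain phenyl group on a saturated chain carbon of its core. Within the data shown here, in a physicochemical assay, read by spectrophotometry, with a stated time of 30 min (on this read-out lower numbers stand for stronger inhibition and higher numbers for weaker inhibition), compound 1 gives 12.4 ug/mL, the lowest of the three numbers measured so far and thus the strongest inhibition among them. Two close relatives are known. Compound 2, `O=C(CC(c1ccc(Cl)cc1)c1c[nH]c2ccccc12)c1c(O)c2ccccc2oc1=O`, gives 46.4 ug/mL in this assay; the step of a 3.7-fold higher number from compound 1 to compound 2 (0.57 log units; beyond the scatter) comes from chloro in place of hydrogen on an aromatic carbon. Compound 3, `O=C(CC(c1ccc(O)cc1)c1c[nH]c2ccccc12)c1c(O)c2ccccc2oc1=O`, gives 58.9 ug/mL; the step of a 4.8-fold higher number from compound 1 to compound 3 (0.68 log units; beyond the scatter) comes from hydroxy in place of hydrogen on an aromatic carbon. Between these two, the step of a 1.3-fold higher number from compound 2 to compound 3 (0.10 log units; within the scatter) is small.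

Compound 4, `O=C(CC(c1ccc(O)c(O)c1)c1c[nH]c2ccccc12)c1c(O)c2ccccc2oc1=O`, has not yet been measured. It differs from compound 1 by 3,4-dihydroxyphenyl in place of phenyl on a saturated chain carbon bound to an aromatic carbon and a saturated chain carbon. The measured step that bears most directly on this change is a 4.8-fold higher number from compound 1 to compound 3 (0.68 log units; beyond the scatter), which followed a single hydroxy in place of hydrogen on an aromatic carbon, and a 3.7-fold higher number from compound 1 to compound 2 (0.57 log units; beyond the scatter) points the same way. A second hydroxy is therefore expected to leave the number above that of compound 1 by a similar or somewhat larger amount. Compound 4 is expected to give about 50 ug/mL in this assay, within the range 18 ug/mL to 130 ug/mL, a step of a 4.0-fold higher number from compound 1 to compound 4 (0.61 log units; beyond the scatter).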

Compound 4, half-maximal inhibitory concentration: 71.1 ug/mL
Estimate against measurement, compound 4: 1.4-fold (0.15 log units) below; the measured number falls inside the stated range.
By their numbers in this assay, from the lowest: compound 1; then compounds 2, 3 and 4 (each within the scatter of the next).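

In this assay the second hydroxy adds nothing that can be told apart: the step of a 1.2-fold higher number from compound 3 to compound 4 (0.08 log units; within the scatter) stays within the scatter, although the whole change on this phenyl amounts to a 5.7-fold higher number from compound 1 to compound 4 (0.76 log units; beyond the scatter) and lies beyond it. Compound 4 also stays within the scatter of the chloro-bearing compound 2, with a 1.5-fold higher number from compound 2 to compound 4 (0.19 log units; within the scatter) as the step, so compounds 2, 3 and 4 form one group at a similar level, and only compound 1, with its unsubstituted phenyl, stands apart from all three. Nothing measured here explains why these groups on the phenyl share this level.

The compounds shown carry only chloro and hydroxy on this phenyl, so it stays open whether an amine or a carboxylic acid on the same ring would give a number close to these or one closer to that of compound 1. From the compounds shown here alone, it is also open whether a longer chain in place of the phenyl, on the same saturated chain carbon, would lower the number further or raise it.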